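A few compounds are considered here, and "the series" means these few. Any claim that something is new, unique, unknown or untested is made for them only; others in the source may bear on it.

For the measured compounds named here, compound 1 `O=C(COC(=O)/C=C/c1ccccc1)NCCC[Te]c1ccccc1` is the one member of the set with a number. In an ADME assay on cells (Fibroblast, Homo sapiens) for cytotoxicity, read by MTT assay, with a stated time of 24 h (a lower number here means a stronger inhibitor, a higher number a weaker inhibitor), compound 1 gives 11000 nM. Compound 2 `COc1ccc(N(CC(=O)NCCCSc2ccccc2)C(=O)/C=C/c2ccccc2)cc1` and compound 3 `COc1ccc(N(CC(=O)NCCCSc2ccccc2)C(=O)C#Cc2ccccc2)cc1` share a second core; how that core differs from the core of compound 1 is not broken down here. For compound 2 the result is a limit of the assay, >= 100000 nM. For compound 3 the result is likewise a limit, >= 100000 nM. Both sit at the limit of >= 100000 nM in this assay, at which 2 of the 3 values shown sit. The change from compound 2 to compound 3 is 2-phenylethynyl in place of 2-phenylethenyl on a carbonyl carbon, and its size is a step that the two limits leave unreadable from compound 2 to compound 3. Compound 4 `O=C(COC(=O)C#Cc1ccccc1)NCCC[Te]c1ccccc1`, yet to be tested, carries the same kind of change on the core of compound 1: 2-phenylethynyl in place of 2-phenylethenyl on a carbonyl carbon. The surroundings of the place differ: in compound 2 the carbonyl carbon's other neighbour is an amide-type nitrogen, in compound 1 an oxygen next to a carbonyl group. The step expected from compound 1 to compound 4 is no change at the digits printed from compound 1 to compound 4 (within the scatter). It rests on nothing beyond the unreadable size of a step that the two limits leave unreadable from compound 2 to compound 3, so a small step is assumed with a wide margin. Compound 4 is accordingly estimated at 11000 nM, between 4000 nM and 40000 nM.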

Compound 4, half-maximal inhibitory concentration: 7000 nM
Compound 4: middle estimate off by 1.6-fold (0.20 log units), on the high side; measured number inside the range.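

In this assay, 2-phenylethynyl in place of 2-phenylethenyl on the carbonyl carbon of the core of compound 1 gives a 1.6-fold lower number from compound 1 to compound 4 (0.20 log units; within the scatter), so on this core the change leaves the read-out as it was. The same change on the second core cannot be read, since compound 2 and compound 3 both stand at a limit of the assay and not at a number: the limit of >= 100000 nM in this assay, at which 2 of the 4 values shown sit. The change has therefore been sized on one core only, and the series shows neither that the step carries over from one core to the other nor that it differs between them.

Open, going by these compounds, is how a 2-phenylethyl group, with neither the double nor the triple bond, would read at the same place on the core of compound 1. Also open, on these data alone, is what an amine or a carboxylic acid on the phenyl ring of either group would do to the read-out.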